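From (oxetan-3-yl)methyl to pyrimidin-2-yl on an aromatic nitrogen

The compounds below may be only part of what the source reports. "The series", "measured", "known", "first", "only" and "open" are said of these compounds alone.

In a functional assay on HT-29 cells (Homo sapiens) for inhibition, read by luminescence and CellTiter-Glo, with a stated time of 24 h (on this read-out higher numbers stand for an effect only at larger amounts of compound and lower numbers for an effect already at smaller amounts), compound 1 `CC(C)n1nc(C(=O)N[C@H]2COc3ccccc3N(C)C2=S)nc1Cc1ccccc1`, with isopropyl on an aromatic nitrogen, gives 360 nM. Compound 2 `CN1C(=S)[C@@H](NC(=O)c2nc(Cc3ccccc3)n(CCC(F)(F)F)n2)COc2ccccc21`, with 3,3,3-trifluoropropyl at that place, gives 1550 nM. Compound 3 `CN1C(=S)[C@@H](NC(=O)c2nc(Cc3ccccc3)n(CC3COC3)n2)COc2ccccc21`, with (oxetan-3-yl)methyl there, gives 2830 nM. Compound 3 thus shares the high end of the numbers with compound 2 and stands clear of compound 1. The measured steps are a 4.3-fold higher number from compound 1 to compound 2 (0.63 log units; beyond the scatter), a 7.9-fold higher number from compound 1 to compound 3 (0.90 log units; beyond the scatter) and a 1.8-fold higher number from compound 2 to compound 3 (0.26 log units; within the scatter).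

Compound 4 `CN1C(=S)[C@@H](NC(=O)c2nc(Cc3ccccc3)n(-c3ncccn3)n2)COc2ccccc21` carries pyrimidin-2-yl in place of (oxetan-3-yl)methyl on an aromatic nitrogen, next to the ring atom that bears a benzyl group: pyrimidin-2-yl in place of (oxetan-3-yl)methyl on an aromatic nitrogen. All three measured steps change this same substituent, so all bear on the new step, but none of them places an aromatic ring on that nitrogen. The two modest steps away from isopropyl show that the number can move with this group, while the last step shows two different groups staying within the scatter. Going by these compounds, with compound 3 at 2830 nM as the starting point, no step beyond the scatter is expected in this assay, although either direction remains open. The expected step is a 1.3-fold lower number from compound 3 to compound 4 (0.11 log units; within the scatter). Compound 4 is estimated at 2200 nM, within an expected range of 500 nM to 9000 nM.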

Compound 4, half-maximal effective concentration: 3970 nM
Beside the measured number, compound 4's estimate is 1.8-fold (0.26 log units) below it; the range from low to high includes it.
By their numbers in this assay, from the lowest: compound 1; then compounds 2, 3 and 4 (each within the scatter of the next, the first and the last beyond it).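

In this assay, among these compounds, pyrimidin-2-yl puts a six-membered aromatic ring on this aromatic nitrogen for the first time, and the result is a 1.4-fold higher number from compound 3 to compound 4 (0.15 log units; within the scatter), so this ring cannot be told apart from (oxetan-3-yl)methyl with its four-membered non-aromatic ring. Among the compounds shown here, the same group can be told apart from 3,3,3-trifluoropropyl, with a 2.6-fold higher number from compound 2 to compound 4 (0.41 log units; beyond the scatter), and the widest gap at this position is an 11-fold higher number from compound 1 to compound 4 (1.04 log units; beyond the scatter), which leaves isopropyl as the only group of the four whose number stands clear of all the others. No measurement at hand accounts for these steps.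

The compounds shown leave open whether the low number belongs to isopropyl alone or also extends to other small carbon groups on this nitrogen, such as methyl, cyclopropyl or tert-butyl. They also leave open whether a phenyl ring, with carbon in place of the pyrimidine nitrogens, or a chain ending in an amine or a carboxylic acid would sit with isopropyl or with the other three groups.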